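The compounds below may be only part of what the source reports. "The series", "measured", "known", "first", "only" and "open" are said of these compounds alone.

Working notes on the series. In a functional assay on HepG2 cells (Homo sapiens) for cytotoxicity, read by colorimetric assay and neutral red uptake, with a stated time of 72 h (on this read-out lower numbers stand for stronger inhibition and higher numbers for weaker inhibition), compound 1 `CO[C@@H](C(=O)N[C@H]1CCCCNC1=O)[C@@H]1OC(C)(C)O[C@H](/C=C/C(C)(C)C)[C@@H]1O` returns no number, only a limit: compound 1 gives > 150000 nM. Compound 2 `CO[C@@H](C(=O)N[C@H]1CC[C@@H](O)CNC1=O)[C@H](O)[C@@H](O)[C@H](O)/C=C/C(C)(C)C` also returns only a limit in this assay: compound 2 gives > 150000 nM. The whole picture so far is the limit of > 150000 nM in this assay, at which 2 of the 2 values shown sit. Among the compounds with values here, no measured step is available to size a change, and neither compound has a true half-maximal value.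

Compound 3 `CO[C@@H](C(=O)N[C@H]1CC[C@H](O)CNC1=O)[C@H](O)[C@@H](O)[C@H](O)/C=C/C(C)(C)C` has no reading yet. The structural change from compound 2 is confined to configuration: the two compounds have the same atoms and bonds and differ only in configuration as drawn: 1 of 7 stereo elements differ; a stereocentre at a saturated ring carbon is drawn R in compound 2 and S in compound 3. No atom or bond leaves or enters.

Within the data shown here, for this assay, no step beyond the scatter is expected in either direction, since the only anchor is compound 2 with > 150000 nM and the series offers no sign of a measurable response. The expected step, a number no higher from compound 2 to compound 3 (the limit leaves the size open), is therefore an estimate with no direction attached to it. Compound 3 is estimated at 150000 nM, with an expected range of 80000 nM to 300000 nM, and a report as a limit rather than a number is the likeliest outcome.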

Compound 3, half-maximal inhibitory concentration: 103000 nM
Compound 3: middle estimate off by 1.5-fold (0.16 log units), on the high side, and the stated range covers the measured number.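

In this assay, within the data shown here, compound 3 gives 103000 nM, the first true half-maximal value, which shows that a number can be obtained within this scaffold and that the stereocentre at a saturated ring carbon is a position where the read-out can be followed. Going from R to S at that stereocentre comes with an at least 1.4-fold lower number from compound 2 to compound 3 (0.16 log units; that floor lies within the scatter); the real size of the step stays open, and nothing printed separates the pair beyond the usual scatter. Whatever difference exists between the two compounds can be tied to this single stereocentre and to nothing else in the structure: the fact that compounds 2 and 3 differ only in the configuration as drawn

The series as shown still offers only one number, so no trend in cytotoxicity can be drawn from it: the limit of > 150000 nM in this assay, at which 2 of the 3 values shown sit. Also open is whether the response at this ring carbon depends on the hydroxyl group itself, for example whether an amine or a carboxylic acid at that carbon would give a number clearly apart from that of compound 3.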